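A few compounds are considered here, and "the series" means these few. Any claim that something is new, unique, unknown or untested is made for them only; others in the source may bear on it.

The series is three measured compounds, compound 1 `COc1ccc(C)cc1NC(=S)N/N=C/c1ccc2ccccc2n1`, compound 2 `S=C(N/N=C/c1ccc2ccccc2n1)Nc1cccc(Cl)c1` and compound 3 `CN(C)C(=S)N/N=C/c1nc2ccccc2s1`, all run in a functional assay on SGC-7901 cells (Homo sapiens) for antiproliferative activity, read by sulforhodamine B assay, with a stated time of 72 h; a higher number here means a weaker inhibitor, a lower number a stronger inhibitor. For compound 1 the result is only a limit of the assay, > 100000 nM; this is the case noted as the limit of > 100000 nM in this assay, at which 1 of the 3 values shown sits. Compound 2 gives 61300 nM, the higher of the two actual numbers; the nearest number belongs to compound 3 at 830 nM, a gap beyond the scatter. From the compounds shown here alone, compound 4, `S=C(N/N=C/c1ccc2ccccc2n1)Nc1cccc(Br)c1`, is untested and differs from compound 2 only by bromo in place of chloro on an aromatic carbon, the 3-chlorophenyl becoming a 3-bromophenyl. Among the measured compounds shown here, no measured pair in the set carries such an exchange, so no step size can be carried over. In this assay little movement is expected from this change, none beyond the scatter; the expected step is a 1.2-fold lower number from compound 2 to compound 4 (0.09 log units; within the scatter). Compound 4 is estimated at 50000 nM, with a range from 20000 nM to 120000 nM.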

Compound 4, half-maximal inhibitory concentration: 78600 nM
Estimate against measurement, compound 4: 1.6-fold (0.20 log units) below; measured number inside the range.
By their numbers in this assay, from the lowest: compound 3; then compounds 2 and 4 (each within the scatter of the next). At a limit, above all of these: compound 1.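

In this assay, bromo in place of chloro on this aromatic carbon, meta to a large group, gives a 1.3-fold higher number from compound 2 to compound 4 (0.11 log units; within the scatter). Among the compounds shown here, this is the first single-place step, and it shows that the two halogens cannot be told apart at this position. Compound 1 is held at a limit of the assay, not a number: the limit of > 100000 nM in this assay, at which 1 of the 4 values shown sits.

Still open, from the compounds shown here alone, is whether a different group on this carbon, such as an amine or a carboxylic acid, would shift the number beyond the scatter. The same exchange elsewhere on the phenyl ring also remains unread.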